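This account rests on a few compounds, and the source may have more. Where it says the series, first, only, none or still open, it means among the compounds named here.

For the measured compounds named here, compound 2 `COC(=O)CSc1nc(N)c(C#N)c(-c2ccc(OCC3CC3)cc2)c1C#N` gives 1% in an assay on CHO cells for displacement of a labelled ligand from adenosine receptor A3 (Homo sapiens), read by scintillation counting, with a stated time of 120 min, tested at 1 uM (a lower number here means less inhibition, a higher number more inhibition at the concentration tested (going by the name of the read-out)), the lowest of the two numbers known here, with compound 1 `N#Cc1c(N)nc(SCC2=NCCN2)c(C#N)c1-c1ccc(OCC2CC2)cc1` nearest at 6%. Compound 3 `CNC(=O)CSc1nc(N)c(C#N)c(-c2ccc(OCC3CC3)cc2)c1C#N` differs from compound 2 by methylamino in place of methoxy on a carbonyl carbon. Going by the values given here, the only measured step, a number 5 percentage points lower from compound 1 to compound 2 (within the scatter), altered a different group and lay within the scatter, so no step bears directly on this change. Both known numbers sit near zero, and compound 3 is therefore expected to show no step beyond the scatter, a number 2 percentage points higher from compound 2 to compound 3 (within the scatter). The estimate for compound 3 is 3%, in the range -6% to 12%.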

Compound 3, a percentage reported as inhibition, at one concentration (the size of the read-out at that concentration, not a potency): 3%
The estimate for compound 3 equals the measured number at the digits printed; measured number inside the range.
By their numbers in this assay, from the lowest: compounds 2, 3 and 1 (each within the scatter of the next).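

Exchanging methoxy for methylamino on the carbonyl carbon gives a number 2 percentage points higher from compound 2 to compound 3 (within the scatter), so this position shows no readable response to that change. Methylcarbamoyl likewise stands level with the five-membered ring group of the first compound, with a number 3 percentage points lower from compound 1 to compound 3 (within the scatter), which extends the earlier flat comparison to a second pair. Nothing available here accounts for these numbers. From the compounds shown here alone, it remains open whether a carboxylic acid or a longer chain amine at this carbonyl carbon would lift the inhibition clear of the scatter. Equally open, going by these compounds, is whether any change elsewhere on the shared core would do so.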